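The source may hold more compounds than are shown below. What is called first, only, known or untested is meant among the compounds shown, and "the series" means these compounds.

Measured compounds:
- compound 1 `CCOc1ccc(OCC(O)CNCCOc2ccccc2OC)cc1`: "not active" (no number reported)
- compound 2 `CCOc1ccc(OCCC(O)CN(C)Cc2c(C)nn(Cc3ccccc3Cl)c2C)cc1`: "not active" (no number reported)
- compound 3 `Cc1nn(Cc2ccccc2Cl)c(C)c1CN(C)CC(O)CCOc1ccc(F)cc1`: 55400 nM

Working notes on the series. In an assay on cells for antagonist activity at Toll-like receptor 4 (Homo sapiens), with a stated time of 24 h (a higher number here means a weaker inhibitor, a lower number a stronger inhibitor), compound 3 gives 55400 nM, the only numerical result in the set. Compound 2 stands without a single number in this assay; its entry reads "not active" (no number reported), and compound 1 is a further entry of the same kind, also without a number. Nothing in the set therefore ranks compound 2 against compound 3 beyond noting that compound 3 has a measured, weak value and compound 2 has none.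

The next compound, compound 4 `Cc1ccc(OCCC(O)CN(C)Cc2c(C)nn(Cc3ccccc3Cl)c2C)cc1`, is to be measured in this assay. It differs from compound 2 in one place: methyl in place of ethoxy on an aromatic carbon. For the measured compounds named here, no step between measured compounds is available to calibrate a change of this kind, so the expected size of the step in this assay is unknown; with compound 2 inactive and compound 3 weak, a result no better than these seems likely, and the most probable outcome is again an inactive entry or a very high number.

Compound 4 is therefore expected to give about 80000 nM in this assay, within a range from 30000 nM to 300000 nM, if a number is reported at all.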

Compound 4, half-maximal inhibitory concentration: 51500 nM
Compound 4: middle estimate off by 1.6-fold (0.19 log units), on the high side; measured number inside the range.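

In this assay, methyl in place of fluoro on this aromatic carbon, para to a large group, gives a 1.1-fold lower number from compound 3 to compound 4 (0.03 log units; within the scatter), so these two groups cannot be told apart at this position. With ethoxy at the same place, compound 2 reads "not active" (no number reported), whereas compound 4, with methyl, gives 51500 nM; the entries therefore differ in kind, a number against none, but the size of this step cannot be read. No measurement available bears on why the ethoxy entry carries no number while the methyl and fluoro entries do.

From the compounds shown here alone, the two numbers in hand come from only methyl and fluoro at this position, so it remains open whether an amine, a carboxylic acid or a nitrile there would give a step beyond the scatter, or whether a longer chain than ethoxy would also leave the entry without a number. Going by these compounds, compound 1 differs from the others in more than one place, so it says nothing about this position, and the effect of changes elsewhere on the shared core also stays open.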